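An Enantiomer Pair Compared for Simulated Intestinal Fluid Solubility

This account rests on a few compounds, and the source may have more. Where it says the series, first, only, none or still open, it means among the compounds named here.

Among the compounds with values here, in a physicochemical assay for solubility, read by HPLC, in simulated intestinal fluid, with a stated time of 16 h, at pH 6.5 (a higher number here means a more soluble compound, a lower number a less soluble compound), compound 2 `CNC(=O)c1cc(C(=O)NC2CC2)cn([C@H](C)c2ccccc2)c1=O` gives 815 ug/mL, the higher of the two numbers so far. Compound 1 `CNC(=O)c1cc(C(=O)N[C@H]2CC[C@H](O)CC2)n([C@@H](C)c2ccccc2)n1` gives 366 ug/mL in this assay, a gap beyond the scatter. Compound 3 `CNC(=O)c1cc(C(=O)NC2CC2)cn([C@@H](C)c2ccccc2)c1=O` has not been measured; its relation to compound 2 is the two compounds have the same atoms and bonds and differ only in configuration as drawn: 1 of 1 stereo elements differ; a stereocentre at a saturated chain carbon is drawn R in compound 2 and S in compound 3. Within the data shown here, no measured pair shows what a change of configuration alone does in this assay, so no step is known. Compound 3 is expected to show no step beyond the scatter, no change at the digits printed from compound 2 to compound 3 (within the scatter). Compound 3 is therefore estimated at 815 ug/mL, with a range from 400 ug/mL to 1600 ug/mL.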

Compound 3, solubility: 699 ug/mL
Beside the measured number, compound 3's estimate is 1.2-fold (0.07 log units) above it, within the range that was stated.
By their numbers in this assay, from the lowest: compounds 1, 3 and 2 (each within the scatter of the next, the first and the last beyond it).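

Changing the stereocentre at the saturated chain carbon from R in compound 2 to S in compound 3 gives a 1.2-fold lower number from compound 2 to compound 3 (0.07 log units; within the scatter) in this assay and so shows no readable effect of configuration at this position. Within the data shown here, this is the first measured pair that isolates configuration alone, which the earlier compounds, differing in more than one place, could not do.

From the compounds shown here alone, it remains open whether configuration at this stereocentre stays equally without effect in compounds that carry an amine or a carboxylic acid. Going by these compounds, it also remains open whether the same holds on the core of compound 1.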